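An allylcarbamoyl group on compound 2

The source may hold more compounds than are shown below. What is called first, only, known or untested is meant among the compounds shown, and "the series" means these compounds.

In a functional assay on MCF7 cells (Homo sapiens) for inhibition (on this read-out lower numbers stand for stronger inhibition and higher numbers for weaker inhibition), compound 1 `CCCCCC[C@@]1(C)SC(=O)C=C1OC` gives 14 ug/mL as a measured number. Compound 2 `CCCCCCCC[C@@]1(C)SC(=O)C=C1OC` gives > 50 ug/mL which is a limit and not a number. Compound 3 `C=CCC1(C)C(=O)S[C@](C)(CCCCCCCC)C1=O` gives > 50 ug/mL which is likewise a limit. Compound 2 thus sits at the limit of > 50 ug/mL in this assay, at which 2 of the 3 values shown sit, and has no exact place on the scale.

Compound 4 `C=CCNC(=O)COC1=CC(=O)S[C@]1(C)CCCCCCCC` has not yet been measured. It comes from compound 2 through one change: allylcarbamoyl in place of hydrogen on a saturated chain carbon bound to an oxygen on an unsaturated carbon and nothing else in the structure differs. In plain terms, allylcarbamoyl takes the place of a hydrogen on a saturated chain carbon bound to an oxygen on an unsaturated carbon.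

Among the measured compounds shown here, the only measured step of an at least 3.5-fold higher number from compound 1 to compound 2 (0.55 log units; beyond the scatter) lies beyond the scatter, but it sits on the saturated chain and not at that place. It shows that a single change can move this read-out, yet it gives neither size nor direction for the allylcarbamoyl group. With compound 2 known only as a limit, no clear step is expected. In this assay the expected outcome is a number no higher from compound 2 to compound 4 (the limit leaves the size open) in this estimate. For compound 4 the estimate is 50 ug/mL with an expected range from 20 ug/mL to 120 ug/mL and a real chance that the outcome is only a limit.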

Compound 4, half-maximal inhibitory concentration: > 50 ug/mL
Compound 4: no number, only a limit; the forecaster's own chance of this, stated with the estimate: 60%; the middle value lies on the limit itself.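

Compound 2 and compound 4 both stand only as limits and not as numbers in this assay, so no step between them can be read: the limit of > 50 ug/mL in this assay, at which 3 of the 4 values shown sit.

The compounds shown leave open whether allylcarbamoyl in place of that hydrogen changes the read-out at all, and if it does, in which direction and by how much.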